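The compounds below may be only part of what the source reports. "The series", "measured", "known", "first", "only" and "open" are said of these compounds alone.

Measured so far:
compound 1, `CCC1=C(O)c2c(oc(-c3cccc(OC)c3)cc2=O)C(CC)(CC)C1=O`: 1.22 uM
compound 2, `CCC1=C(O)c2c(oc(-c3cccc(OC)c3OC)cc2=O)C(CC)(CC)C1=O`: 4.02 uM
compound 3, `CCC1=C(O)c2c(oc(-c3cc(OC)ccc3OC)cc2=O)C(CC)(CC)C1=O`: 2.51 uM

In a functional assay on KBVIN cells (Homo sapiens) for antiproliferative activity, read by sulforhodamine B assay, with a stated time of 3 days (on this read-out higher numbers stand for an effect only at larger amounts of compound and lower numbers for an effect already at smaller amounts), compound 1 gives the lowest of the three numbers. Its nearest neighbour is compound 3, and the step of a 2.1-fold higher number from compound 1 to compound 3 (0.31 log units; beyond the scatter) is modest; the furthest is compound 2, where a 3.3-fold higher number from compound 1 to compound 2 (0.52 log units; beyond the scatter) is also modest. Both of those steps add a methoxy on an aromatic carbon of the pendant ring, and both raise the number.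

Compound 4, `CCC1=C(O)c2c(oc(-c3ccc(F)c(C)c3)cc2=O)C(CC)(CC)C1=O`, has not yet been measured in this assay. It differs from compound 1 in one place: 4-fluoro-3-methylphenyl in place of 3-methoxyphenyl on an aromatic carbon. Neither measured step matches this change, since each of them adds a group rather than exchanging the whole pendant ring, so they bear on it only loosely. They show that small changes on this ring move the number by modest amounts, with no sign of a large swing. Compound 4 is therefore expected to land close to compound 1, with a step in either direction that need not exceed the scatter. Compound 4 is estimated at 1.6 uM, in the range 0.6 uM to 4.5 uM. That estimate amounts to a 1.3-fold higher number from compound 1 to compound 4 (0.12 log units; within the scatter).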

Compound 4, concentration for half-maximal effect: 1.62 uM
Estimate against measurement, compound 4: 1.0-fold (0.01 log units) below; low and high end bracket the measured number.
By their numbers in this assay, from the lowest: compounds 1, 4, 3 and 2 (each within the scatter of the next, the first and the last beyond it).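

In this assay, exchanging the 3-methoxyphenyl of compound 1 for 4-fluoro-3-methylphenyl gives a 1.3-fold higher number from compound 1 to compound 4 (0.12 log units; within the scatter), so the methoxy oxygen and its hydrogen-bond acceptor are not needed at this position to keep the number level with compound 1. The earlier compounds shown here only added a second methoxy to the ring, and each of those steps went beyond the scatter, whereas this exchange of substituents, with the same count of heavy atoms in the group, stays within it. No measurement at hand offers a reason for this result.

The compounds shown do not separate what the fluorine and the methyl each contribute, since the two enter together. They also leave open how this position would respond to an amine, a carboxylic acid or a longer chain such as butoxy on the ring.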